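The source may report more compounds than this note shows. Statements on the series, on what has been measured and on what is new or still open speak of the compounds shown alone.

Measured in an ADME assay on microsomes from liver (Rattus norvegicus) for metabolic stability, read by LC-MS, using NADPH, tested at 3 uM; on this read-out lower numbers stand for a shorter-lived compound and higher numbers for a longer-lived compound:
Compound 1 `Cc1ccc2c(C(C(=O)C(F)(F)F)c3ccccc3)c(-c3ccccc3)[nH]c2c1`: 0.413 h
Compound 2 `Cc1ccc2c(C(CC(F)(F)F)c3ccccc3)c(-c3ccccc3)[nH]c2c1`: 0.47 h

Compound 2, at 0.47 h, stands level with compound 1 within the scatter. Compound 3 `FC(F)(F)CC(c1ccccc1)c1c(-c2ccccc2)[nH]c2cc(Cl)ccc12` has chloro in place of methyl on an aromatic carbon. Within the data shown here, the only measured step, a 1.1-fold higher number from compound 1 to compound 2 (0.06 log units; within the scatter), lies within the scatter and concerns a group on a saturated chain carbon, so it bears only indirectly on this change. Among the measured compounds shown here, no measured step covers this swap, and no shift beyond the scatter is expected in this assay, in either direction. The expected size is a 1.2-fold higher number from compound 2 to compound 3 (0.07 log units; within the scatter). Compound 3 is estimated at 0.55 h, with an expected range of 0.27 h to 1.1 h.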

Compound 3, half-life: 1.3 h
Beside the measured number, compound 3's estimate is 2.4-fold (0.37 log units) below it; the whole stated range lies below it.
By their numbers in this assay, from the lowest: compounds 1 and 2 (each within the scatter of the next); then compound 3.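

In this assay, chloro in place of methyl on an aromatic carbon gives a 2.8-fold higher number from compound 2 to compound 3 (0.44 log units; beyond the scatter) and is a modest step beyond the scatter. The half-life therefore responds to a change at this position, meta to a fused ring and para to a fused ring, whereas the earlier change on the saturated chain carbon stayed within the scatter. Nothing available explains this shift. The compounds shown leave open whether fluoro, a nitrile or a methoxy group here would lengthen the half-life as well. They also leave open whether chloro would have the same effect with the (trifluoromethyl)carbonyl group on the chain.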